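From a basic amine tail to a methoxy tail

The source may hold more compounds than are shown below. What is called first, only, known or untested is meant among the compounds shown, and "the series" means these compounds.

Compound 2 `CCCn1c(=O)n(C)c(=O)c2c1ncn2CCN(C)C` carries a 2-(dimethylamino)ethyl chain on the shared core. In an assay on Cerebral cortex for binding affinity to adenosine receptor A1 (Cavia porcellus), read by radioligand binding (a higher number here means a weaker inhibitor, a lower number a stronger inhibitor), compound 2 reaches only the limit of the assay, > 200000 nM. Its neighbour, compound 1 `CCCn1c(=O)n(C)c(=O)c2c1ncn2CC#N`, has a cyanomethyl chain in the same place, and in this assay compound 1 gives 6600 nM. For the measured compounds named here, the one step that connects them, an at least 30-fold higher number from compound 1 to compound 2 (1.48 log units; beyond the scatter), rests on (the limit of > 200000 nM in this assay, at which 1 of the 2 values shown sits), so its true size is not known beyond being large.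

Compound 3 `CCCn1c(=O)n(C)c(=O)c2c1ncn2CCOC` is not yet measured in this assay. Its change from compound 2 is methoxy in place of dimethylamino on a saturated chain carbon, two bonds along the chain from an aromatic nitrogen. Going by the values given here, the only measured step that bears on this chain, an at least 30-fold higher number from compound 1 to compound 2 (1.48 log units; beyond the scatter), shows that exchanging the cyano tail for the dimethylamino tail costs a great deal; compound 3 removes that dimethylamino group again, but replaces it with methoxy rather than cyano, and no measured pair shows what methoxy does here. A step back toward the level of compound 1 is therefore expected, of uncertain size.

In this assay compound 3 is estimated at 15000 nM, within 3000 nM to 100000 nM. This estimate means an expected at least 13-fold lower number from compound 2 to compound 3 (1.12 log units; beyond the scatter).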

Compound 3, inhibition constant: 12400 nM
Compound 3: the middle estimate sits 1.2-fold (0.08 log units) above what was measured; the measured number falls inside the stated range.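

In this assay, methoxy in place of dimethylamino on this saturated chain carbon gives an at least 16-fold lower number from compound 2 to compound 3 (1.20 log units; beyond the scatter), so the large rise seen on going to compound 2 is now bracketed by steps from two different tails, cyanomethyl and 2-methoxyethyl. As far as these compounds go, compound 2 stands at a limit of the assay, so the true size of that step remains unknown: the limit of > 200000 nM in this assay, at which 1 of the 3 values shown sits. The other new step, a 1.9-fold higher number from compound 1 to compound 3 (0.27 log units; within the scatter), lies within the scatter, so the cyanomethyl and 2-methoxyethyl chains cannot be told apart here, and of the three chains on the shared core only 2-(dimethylamino)ethyl stands apart.

The compounds shown leave open whether the high number belongs to dimethylamino alone or would also come with another amine on the same chain, such as an unsubstituted amino group or a pyrrolidine. They also do not say how a 2-hydroxyethyl chain, a carboxylic acid at the chain end or a longer chain ending in methoxy would read in this assay.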